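The source may hold more compounds than are shown below. What is called first, only, known or untested is meant among the compounds shown, and "the series" means these compounds.

Of the compounds shown here, three of one series have been measured in a functional assay on HOP-92 cells (Homo sapiens) for inhibition, read by sulforhodamine B assay, with a stated time of 48 h; a lower number here means a stronger inhibitor, a higher number a weaker inhibitor. Compound 1 `O=C(Nc1cccc(-n2cc(-c3ccncc3)c(-c3ccc(Cl)c(O)c3)n2)c1)Nc1cccc(C(F)(F)F)c1` gives 510 nM. Compound 2 `COc1cc(-c2nn(-c3cccc(NC(=O)c4cccc(C(F)(F)F)c4)c3)cc2-c2ccncc2)ccc1Cl` gives 560 nM. Compound 3 `COc1cc(-c2nn(-c3cccc(NC(=O)Nc4ccc(Cl)c(Cl)c4)c3)cc2-c2ccncc2)ccc1Cl` gives 150 nM, the lowest of the three numbers, with compound 1 nearest and compound 2 furthest, both beyond the scatter. Within the data shown here, the only single-point step among them, a 3.7-fold lower number from compound 2 to compound 3 (0.57 log units; beyond the scatter), concerns the group on the carbonyl carbon and not the oxygen.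

Compound 4 `O=C(Nc1cccc(-n2cc(-c3ccncc3)c(-c3ccc(Cl)c(O)c3)n2)c1)Nc1ccc(Cl)c(Cl)c1` differs from compound 3 by hydrogen in place of methyl on an oxygen on an aromatic ring. Among the measured compounds shown here, no measured step isolates this change: compound 1 and compound 2 carry different groups both on that oxygen and on the carbonyl carbon, and their two values sit within the scatter of each other, so nothing can be read from them about the oxygen alone. The step from compound 2 to compound 3 does not bear on it. With no evidence that a methyl on this oxygen matters, the expected step of a 1.1-fold higher number from compound 3 to compound 4 (0.05 log units; within the scatter) is none beyond the scatter. Compound 4 is therefore estimated at 170 nM in this assay, in a range from 70 nM to 400 nM.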

Compound 4, half-maximal inhibitory concentration: 680 nM
Compound 4: middle estimate off by 4.0-fold (0.60 log units), on the low side; the measured number lies above the stated range.
By their numbers in this assay, from the lowest: compound 3; then compounds 1, 2 and 4 (each within the scatter of the next).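

In this assay the methyl on this oxygen proves to count, at least with 3,4-dichlorophenyl on the amide-type nitrogen: replacing methoxy with hydroxy gives a 4.5-fold higher number from compound 3 to compound 4 (0.66 log units; beyond the scatter) and so removes the separation that compound 3 held over the other compounds. The other new step, a 1.3-fold higher number from compound 1 to compound 4 (0.12 log units; within the scatter), shows that once hydroxy stands on the aromatic ring, exchanging 3-(trifluoromethyl)phenyl for 3,4-dichlorophenyl on the amide-type nitrogen does not separate the two compounds, so the methoxy and hydroxy forms do not respond alike across the series as far as these compounds show. Nothing given here explains why the methyl matters or why the exchange on the nitrogen leaves no mark in the hydroxy pair.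

The methoxy partner of compound 1 is not among the compounds shown, so it remains open whether the step from methoxy to hydroxy has the same size with 3-(trifluoromethyl)phenyl on the amide-type nitrogen. On these data alone, it is also open whether an ethoxy group or an amine in place of the methoxy would read like compound 3 or like compound 4.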